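Dichlorination of the anilide ring in an isatin hydrazone series

The source may report more compounds than this note shows. Statements on the series, on what has been measured and on what is new or still open speak of the compounds shown alone.

Measured compounds:
Compound 1, `Cc1ccc(NC(=O)CN2C(=O)/C(=N\NC(=O)Cn3ccc(=O)c(O)c3C)c3ccccc32)cc1`: 47500 nM
Compound 2, `Cc1c(O)c(=O)ccn1CC(=O)N/N=C1\C(=O)N(CC(=O)Nc2ccccc2)c2ccccc21`: 29200 nM

In a functional assay on A549 cells (Homo sapiens) for cytotoxicity, read by MTT assay, with a stated time of 48 h (on this read-out higher numbers stand for an effect only at larger amounts of compound and lower numbers for an effect already at smaller amounts), compound 1 gives 47500 nM and compound 2 gives 29200 nM. Going by the values given here, the two share the same core and differ only on the anilide ring; the step of a 1.6-fold lower number from compound 1 to compound 2 (0.21 log units; within the scatter) places compound 2 alongside compound 1 rather than apart from it, so on the two numbers known compound 2 stands at one end, but not beyond the scatter of the other.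

Compound 3, `Cc1c(O)c(=O)ccn1CC(=O)N/N=C1\C(=O)N(CC(=O)Nc2ccc(Cl)cc2Cl)c2ccccc21`, has not yet been measured in this assay. It carries 2,4-dichlorophenyl in place of phenyl on an amide-type nitrogen. Among the compounds with values here, the only measured step, a 1.6-fold lower number from compound 1 to compound 2 (0.21 log units; within the scatter), concerns the same anilide ring but a different group, so it bears on compound 3 only loosely: it shows that altering this ring once left the number within the scatter. Because a 1.6-fold lower number from compound 1 to compound 2 (0.21 log units; within the scatter) was small, the step of a 1.5-fold lower number from compound 2 to compound 3 (0.16 log units; within the scatter) is expected to be modest as well, most likely a somewhat lower number, though none beyond the scatter would be unsurprising. The estimate for compound 3 in this assay is therefore 20000 nM, within a range from 7000 nM to 60000 nM.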

Compound 3, half-maximal effective concentration: 61500 nM
Beside the measured number, compound 3's estimate is 3.1-fold (0.49 log units) below it; the measured number lies above the stated range.
By their numbers in this assay, from the lowest: compounds 2, 1 and 3 (each within the scatter of the next, the first and the last beyond it).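

In this assay, going by these compounds alone, the place on the amide-type nitrogen now yields a step beyond the scatter for the first time: 2,4-dichlorophenyl in place of phenyl gives a 2.1-fold higher number from compound 2 to compound 3 (0.32 log units; beyond the scatter) and so stands apart from the earlier change at this place, which stayed within the scatter. Set against 4-methylphenyl, the same 2,4-dichlorophenyl group gives a 1.3-fold higher number from compound 1 to compound 3 (0.11 log units; within the scatter) and leaves compound 3 indistinguishable from compound 1, so among these three groups the only separation lies between phenyl and 2,4-dichlorophenyl, and that separation is modest. No supporting measurement bears on this step, and the data offer no account of it.

The compounds shown leave open whether both chlorines are needed for this step or whether a ring carrying a single chlorine would give the same result. They also leave open how the number would respond to a different kind of group on this ring, such as an amine or a carboxylic acid, and whether any such group would move it away from the narrow span seen so far.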